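The compounds below may be only part of what the source reports. "The series", "measured", "known", "first", "only" and "open" are said of these compounds alone.

Three compounds share one core and differ only in the group hung on the chain that leaves the aromatic nitrogen. Compound 1 `O=S(=O)(NCCNc1nccc(-c2c(-c3cccc(F)c3)nc3sccn23)n1)c1ccc(Cl)cc1` carries a (4-chlorophenyl)sulfonyl group and gives 18600 nM in a functional assay on A-375 cells (Homo sapiens) for cytotoxicity, read by MTT assay; a lower number here means a stronger inhibitor, a higher number a weaker inhibitor. Compound 2 `O=C(NCCNc1nccc(-c2c(-c3cccc(F)c3)nc3sccn23)n1)c1ccc(Cl)cc1` carries a (4-chlorophenyl)carbonyl group instead and gives 2570 nM in this assay. Compound 3 `O=S(=O)(NCCNc1nccc(-c2c(-c3cccc(F)c3)nc3sccn23)n1)c1ccccc1` carries a phenylsulfonyl group and gives 11000 nM in this assay; it stands second highest of the three numbers, close to compound 1 and farther from compound 2. The step of a 1.7-fold lower number from compound 1 to compound 3 (0.23 log units; within the scatter) lies within the scatter, while the step of a 7.2-fold lower number from compound 1 to compound 2 (0.86 log units; beyond the scatter) and the step of a 4.3-fold higher number from compound 2 to compound 3 (0.63 log units; beyond the scatter) both show that a carbonyl in place of a sulfonyl goes with a lower number.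

Compound 4 `O=C(NCCCNc1nccc(-c2c(-c3cccc(F)c3)nc3sccn23)n1)c1ccc(F)cc1` changes the same region: (((4-fluorophenyl)carbonyl)amino)methyl in place of (phenylsulfonyl)amino on a saturated chain carbon, two bonds along the chain from a nitrogen on an aromatic ring. Part of this change, sulfonyl to carbonyl, matches the measured steps from compound 1 to compound 2 and from compound 2 to compound 3; the longer chain and the fluoro in place of chloro or hydrogen have no measured counterpart here. A modest drop in this assay is therefore expected, roughly a 3.7-fold lower number from compound 3 to compound 4 (0.56 log units; beyond the scatter). Compound 4 is estimated at 3000 nM, within a range from 800 nM to 12000 nM.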

Compound 4, half-maximal inhibitory concentration: 14900 nM
Estimate against measurement, compound 4: 5.0-fold (0.70 log units) below; the measured number lies above the stated range.
By their numbers in this assay, from the lowest: compound 2; then compounds 3, 4 and 1 (each within the scatter of the next).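

In this assay, within the data shown here, a carbonyl does not by itself bring the lower number: the change to (((4-fluorophenyl)carbonyl)amino)methyl gives a 5.8-fold higher number from compound 2 to compound 4 (0.76 log units; beyond the scatter) and so compound 4 goes against the link between carbonyl and lower number seen in the earlier compounds. Against the two sulfonyl compounds, the same change gives a 1.4-fold higher number from compound 3 to compound 4 (0.13 log units; within the scatter) and a 1.2-fold lower number from compound 1 to compound 4 (0.10 log units; within the scatter) and both steps stay within the scatter, so this carbonyl compound reads level with them. No supporting data are available to explain this result.

The step away from compound 2 combines the longer chain with fluoro in place of chloro, and the compounds shown cannot separate the two. As far as these compounds go, a 4-chlorophenyl carbonyl group on the longer chain would pull them apart, and an even longer chain remains open as well.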